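Compound 3: replacing ureido with 4-methylpiperazin-1-yl

A few compounds are considered here, and "the series" means these few. Any claim that something is new, unique, unknown or untested is made for them only; others in the source may bear on it.

Measured in a functional assay on KB cells (Homo sapiens) for cytotoxicity, read by MTT assay, with a stated time of 3 days; on this read-out higher numbers stand for weaker inhibition and lower numbers for stronger inhibition:
Compound 1 `N#Cc1c(NN)nc(SCc2nc3ccccc3[nH]2)nc1-c1ccccc1`: 2.55 nM
Compound 2 `N#Cc1c(NC(N)=O)nc(SCc2nc3ccccc3[nH]2)nc1-c1ccccc1`: 9.6 nM

Of the two numbers, compound 2 has the higher, at 9.6 nM, so it is the weaker inhibitor of the pair. The next compound is compound 3 `CN1CCN(c2nc(SCc3nc4ccccc4[nH]3)nc(-c3ccccc3)c2C#N)CC1`, with 4-methylpiperazin-1-yl in place of ureido on an aromatic carbon. Among the compounds with values here, only one measured step bears on this change: a 3.8-fold higher number from compound 1 to compound 2 (0.58 log units; beyond the scatter). Within the data shown here, that step is modest and beyond the scatter, but it involves no ring, and no compound with a ring at this place has been measured. The direction is therefore weakly supported. A modest upward step of similar size is tentatively expected in this assay. The expected step is a 2.6-fold higher number from compound 2 to compound 3 (0.42 log units; beyond the scatter). For compound 3 the estimated value is 25 nM, with an expected range of 5 nM to 120 nM.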

Compound 3, half-maximal inhibitory concentration: 2.7 nM
Beside the measured number, compound 3's estimate is 9.3-fold (0.97 log units) above it; measured number below the stated range.
By their numbers in this assay, from the lowest: compounds 1 and 3 (each within the scatter of the next); then compound 2.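

At this aromatic carbon, ortho to a cyano group, a six-membered non-aromatic ring is now shown to be compatible with a low number in this assay: 4-methylpiperazin-1-yl in place of ureido gives a 3.6-fold lower number from compound 2 to compound 3 (0.55 log units; beyond the scatter), so the hydrogen-bond donors of ureido are not needed for a low number here. The same group in place of aminoamino gives a 1.1-fold higher number from compound 1 to compound 3 (0.02 log units; within the scatter), which means that two very different groups at this place, one with a ring and one without, cannot be told apart on this read-out. Nothing at hand accounts for either step.

The compounds shown leave open whether the low number of compound 3 depends on the ring, its second nitrogen or its methyl group. Morpholin-4-yl, piperidin-1-yl or an open-chain dimethylamino group at this carbon would separate these three.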